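The compounds below may be only part of what the source reports. "The series", "measured", "known", "first", "only" and "open" are said of these compounds alone.

Measured so far in an assay on HEK293 cells for positive allosteric modulation of metabotropic glutamate receptor 3 (Rattus norvegicus), read by thallium flux, with a stated time of 2.5 min; a higher number here means a larger maximal response, a lower number a smaller maximal response:
Compound 1 `COc1cc(C(=O)O)ccc1OCCCCOc1ccc(C(=O)C(C)C)c(O)c1C` gives 25.6%.
Compound 2 `CC(=O)c1ccc(OCCCCOc2ccc(C(=O)O)cc2C)c(C)c1O` gives 25.4%.

Compound 2 and compound 1 lie within the scatter of each other in this assay, so neither can be placed above the other; the two numbers simply agree.

Compound 3 `COc1cc(C(=O)O)ccc1OCCCCOc1ccc(C(C)=O)c(O)c1C` is the next member. It differs from compound 2 by methoxy in place of methyl on an aromatic carbon.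

Among the compounds with values here, no measured pair shows this change, so nothing fixes its size. The expectation is that the step of a number 0.6 percentage points higher from compound 2 to compound 3 (within the scatter) stays within the scatter, with no direction beyond it.

Compound 3 is therefore estimated at 26%, range 15% to 40%.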

Compound 3, largest response reached (reported as percent of maximum), in percent of the reference or control that the assay uses: 26.3%
For compound 3 the middle estimate is 0.3 percentage points below the measured one, within the range that was stated.
By their numbers in this assay, from the lowest: compounds 2, 1 and 3 (each within the scatter of the next).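

In this assay, methoxy in place of methyl on an aromatic carbon, ortho to a large group and meta to a carboxy group, gives a number 0.9 percentage points higher from compound 2 to compound 3 (within the scatter) and so shows no readable change at this position. Methyl in place of isopropyl on a carbonyl carbon gives a number 0.7 percentage points higher from compound 1 to compound 3 (within the scatter) and likewise shows no readable change at that second position. Nothing available explains why either exchange leaves the maximal response within the scatter.

Open, from the compounds shown here alone, is whether an amide in place of the carboxy group would move the maximal response beyond the scatter. The same holds for a longer chain joining the two halves of the core.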